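The source may hold more compounds than are shown below. What is called first, only, known or untested is meant among the compounds shown, and "the series" means these compounds.

Compound 1, `Fc1ccccc1NC(=S)Nc1cccc(C(F)(F)F)c1`, gives 47000 nM in an ADME assay on MT4 cells (Homo sapiens) for cytotoxicity; on this read-out lower numbers stand for higher toxicity in this test and higher numbers for lower toxicity in this test.
Compound 2, `CCNC(=S)Nc1cccc(C(F)(F)F)c1`, gives > 100000 nM in this assay; this is a limit of the assay and not a number.
Compound 3, `C=C(C)CNC(=S)Nc1cccc(C(F)(F)F)c1`, gives 43000 nM in this assay.

Among the two numbers that are not limits, compound 3 has the lowest, and its nearest neighbour is compound 1, with a 1.1-fold lower number from compound 1 to compound 3 (0.04 log units; within the scatter), a gap within the scatter. Compound 2 sits at the limit (the limit of > 100000 nM in this assay, at which 1 of the 3 values shown sits), so the step of an at least 2.3-fold lower number from compound 2 to compound 3 (0.36 log units; beyond the scatter) is at least modest, as is an at least 2.1-fold higher number from compound 1 to compound 2 (0.32 log units; beyond the scatter).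

Compound 4, `FC(F)(F)c1cccc(NC(=S)Nc2ccccc2Br)c1`, differs from compound 3 in one place: 2-bromophenyl in place of 2-methylprop-2-en-1-yl on an amide-type nitrogen. Going by the values given here, the step that bears most on this change is the one from compound 1 to compound 3, which exchanges a 2-fluorophenyl for the same 2-methylprop-2-en-1-yl group on the same nitrogen and stays within the scatter. Moving back from that chain to an aromatic ring, now a 2-bromophenyl, is therefore expected to change this assay little, with a 1.0-fold higher number from compound 3 to compound 4 (0.02 log units; within the scatter) as the estimated step. Compound 4 is expected to give about 45000 nM, between 20000 nM and 100000 nM.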

Compound 4, half-maximal cytotoxic concentration: 36000 nM
Beside the measured number, compound 4's estimate is 1.3-fold (0.10 log units) above it; measured number inside the range.
By their numbers in this assay, from the lowest: compounds 4, 3 and 1 (each within the scatter of the next). At a limit, above all of these: compound 2.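

In this assay, the change on the amide-type nitrogen from an open chain to an aromatic ring gives a 1.2-fold lower number from compound 3 to compound 4 (0.08 log units; within the scatter), so 2-methylprop-2-en-1-yl and 2-bromophenyl cannot be told apart at this position. The result also adds the first comparison made on the aromatic ring itself: bromo in place of fluoro on the aromatic carbon gives a 1.3-fold lower number from compound 1 to compound 4 (0.12 log units; within the scatter), so this exchange of halogens does not separate compound 1 from compound 4 either. Ethyl remains the only group shown that stands apart from the others, with an at least 2.7-fold lower number from compound 2 to compound 4 (0.44 log units; beyond the scatter), but that step rests on compound 2, whose value is a limit and not a number: the limit of > 100000 nM in this assay, at which 1 of the 4 values shown sits.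

The compounds shown leave open how far the higher number seen with ethyl extends among saturated groups on this nitrogen, for instance a longer chain such as n-butyl, or a ring such as cyclohexyl. They also leave open whether a group of a different kind on the aromatic ring, such as an amine or a carboxylic acid in place of the bromo, would move the number beyond the scatter.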